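This account rests on a few compounds, and the source may have more. Where it says the series, first, only, none or still open, it means among the compounds named here.

Compound 1 `CC(=O)OC(C)n1cnc2c(Cl)nc(I)nc21` gives 13000 nM in a functional assay on L1210 cells (Mus musculus) for inhibition; a higher number here means a weaker inhibitor, a lower number a stronger inhibitor; compound 2 `CC(=O)OC(C)n1cnc2c(Cl)nc(F)nc21` gives 37000 nM in this assay.

Compound 2 stands at the highest of the two numbers; its nearest neighbour is compound 1, and the step of a 2.8-fold higher number from compound 1 to compound 2 (0.45 log units; beyond the scatter) lies beyond the scatter. Compound 3 `CC(=O)OC(C)n1cnc2c(S)nc(F)nc21` differs from compound 2 by sulfanyl in place of chloro on an aromatic carbon. Among the measured compounds shown here, no measured step touches this position or this exchange: the one step known, from iodo to fluoro, concerns the other ring carbon, so it says nothing direct about replacing chloro by sulfanyl. With only the value of compound 2 as anchor, the expected step of a 1.1-fold higher number from compound 2 to compound 3 (0.03 log units; within the scatter) is therefore small and its direction uncertain. For compound 3 the estimate in this assay is 40000 nM, with a range from 10000 nM to 160000 nM.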

Compound 3, half-maximal inhibitory concentration: 226000 nM
Beside the measured number, compound 3's estimate is 5.7-fold (0.75 log units) below it; the measured number lies above the stated range.
By their numbers in this assay, from the lowest: compound 1; then compound 2; then compound 3.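

Among the compounds shown here, replacing chloro with sulfanyl on the aromatic carbon next to the ring nitrogen gives the first reading at this position: in this assay the change brings a 6.1-fold higher number from compound 2 to compound 3 (0.79 log units; beyond the scatter) and so a weaker inhibitor. The earlier step concerned only the halogen on the other ring carbon, so this result adds that the position opposite the ring nitrogen's neighbouring fluoro-bearing side is not indifferent to exchange. It rests on a single pair, however, and no measurement offered here accounts for the loss.

The compounds shown leave open whether the loss belongs to sulfanyl alone or would also follow an amine, a methoxy group or a methylsulfanyl group at this position. They also leave open whether the same exchange would give a step of similar size with iodo in place of fluoro on the other ring carbon.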